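Shortening the Capsaicin-Like Tail to a Cyclopropyl End

The source may report more compounds than this note shows. Statements on the series, on what has been measured and on what is new or still open speak of the compounds shown alone.

Compound 1, `CCCCCC/C=C/C#CCCCCCCCC(=O)NCc1ccc(O)c(OC)c1`, gives 1.26 nM in a functional assay on HEK293 cells with transient receptor potential cation channel subfamily V member 1 (Homo sapiens) as the target; a higher number here means that more compound is needed for the effect, a lower number that less compound is needed.
Compound 2, `CCCCCCC(=O)CCCCCCCCCCC(=O)NCc1ccc(O)c(OC)c1`, gives 6.31 nM in this assay.

Of the two compounds measured, compound 2 has the higher number; the gap to compound 1 is beyond the usual scatter of repeated measurements. Compound 3, `COc1cc(CNC(=O)CCCCCCCCC2CC2)ccc1O`, differs from compound 2 by cyclopropyl in place of 2-(hexylcarbonyl)ethyl on a saturated chain carbon, eight bonds along the chain from a carbonyl carbon. The long tail that carries a ketone in compound 2 is thus cut back to a short chain ending in a small ring. Within the data shown here, no measured pair shows a step of this kind, so the expectation rests only on the two values above and on the size of the change. Compound 3 is expected to need more compound than compound 2, with the expected step being a 9.5-fold higher number from compound 2 to compound 3 (0.98 log units; beyond the scatter). Compound 3 is estimated at 60 nM, with a range from 10 nM to 500 nM.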

Compound 3, half-maximal effective concentration: 3.16 nM
Compound 3: middle estimate off by 19-fold (1.28 log units), on the high side; measured number outside the range, below it.
By their numbers in this assay, from the lowest: compound 1; then compounds 3 and 2 (each within the scatter of the next).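

In this assay the move from the long ketone-bearing tail to the short ring end gives a 2.0-fold lower number from compound 2 to compound 3 (0.30 log units; within the scatter) and so does not separate the two compounds, which shows that at this saturated chain carbon, eight bonds along the chain from a carbonyl carbon, 2-(hexylcarbonyl)ethyl can give way to cyclopropyl with the number staying in the low range of the series. The unsaturated tail of compound 1 still keeps a small edge, with a 2.5-fold higher number from compound 1 to compound 3 (0.40 log units; beyond the scatter) as a modest step that lies beyond the scatter. No separate measurement bears on these steps.

On these data alone, what remains open is whether the three-membered ring itself matters, or whether a plain propyl end or a cyclobutyl ring at this place would serve equally well. A carboxylic acid or an amine at the chain end also remains untested among the compounds shown.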